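The source may hold more compounds than are shown below. What is called first, only, known or untested is meant among the compounds shown, and "the series" means these compounds.

Measured compounds:
compound 1, `COc1cc(-c2cc(/C=C/C(=O)c3ccc(N)cc3)[nH]n2)cc(OC)c1OC`, 85%
compound 2, `COc1ccc(C(=O)/C=C/c2cc(-c3cc(OC)c(OC)c(OC)c3)n[nH]2)cc1OC`, 95%
Not yet measured: compound 3, `COc1ccc(C(=O)/C=C/c2cc(-c3cc(OC)c(OC)c(OC)c3)n[nH]2)cc1`.

In a functional assay on OVCAR-4 cells (Homo sapiens) for cytotoxicity, read by sulforhodamine B assay, with a stated time of 48 h, tested at 0.01 uM (on this read-out lower numbers stand for a stronger effect and higher numbers for a weaker effect at the one concentration tested), compound 2 gives 95%, the highest of the two numbers; its nearest neighbour is compound 1, which in this assay gives 85%, and the step of a number 10 percentage points higher from compound 1 to compound 2 (within the scatter) lies within the scatter. Compound 3 differs from compound 2 by hydrogen in place of methoxy on an aromatic carbon. Among the compounds with values here, no measured step touches this position: the only step known, from compound 1 to compound 2, changes the group on the carbonyl carbon and not the methoxy here, and it was itself within the scatter. There is thus nothing in the numbers pointing to a step beyond the scatter in this assay, in either direction. Compound 3 is therefore expected to sit close to compound 2, a step of a number 2 percentage points lower from compound 2 to compound 3 (within the scatter). The estimate for compound 3 in this assay is 93%, with a range from 80% to 104%.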

Compound 3, a percentage reported as activity, at one concentration (the size of the read-out at that concentration, not a potency): 91%
Compound 3: middle estimate off by 2 percentage points, on the high side; measured number inside the range.
By their numbers in this assay, from the lowest: compounds 1, 3 and 2 (each within the scatter of the next).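

In this assay, within the data shown here, hydrogen in place of methoxy gives a number 4 percentage points lower from compound 2 to compound 3 (within the scatter), the first reading at this position, and taking 3,4-dimethoxyphenyl to 4-methoxyphenyl does not carry the number beyond the scatter. Methoxy in place of amino on the same aromatic carbon gives a number 6 percentage points higher from compound 1 to compound 3 (within the scatter), so 4-aminophenyl, 4-methoxyphenyl and 3,4-dimethoxyphenyl are not told apart at the one concentration tested. No measurement is at hand that would account for this result.

From the compounds shown here alone, whether a hydroxyl group, a fluorine atom or a carboxylic acid on this ring would move the number beyond the scatter remains open. Going by these compounds, with all three compounds within the scatter of one another at a single concentration, it also remains open whether these groups would separate at other concentrations.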